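Amine chain variation on a fluoroindole core

The source may report more compounds than this note shows. Statements on the series, on what has been measured and on what is new or still open speak of the compounds shown alone.

Compound 1, `CCN(CC)Cc1c[nH]c2ccc(F)cc12`, in an assay on isolated protein for inhibition of Myeloperoxidase (Homo sapiens) (on this read-out lower numbers stand for stronger inhibition and higher numbers for weaker inhibition), gives > 1000 nM.
Compound 2, `CNCCCc1c[nH]c2ccc(F)cc12`, in this assay gives 26 nM.
Compound 3, `CCCNCCCc1c[nH]c2ccc(F)cc12`, in this assay gives 340 nM.

The value of compound 1 is a limit of this assay and not a number (the limit of > 1000 nM in this assay, at which 1 of the 3 values shown sits). Of the two numbers, compound 3 stands at the higher one; the step of a 13-fold higher number from compound 2 to compound 3 (1.12 log units; beyond the scatter) runs beyond the scatter. The step of an at least 38-fold lower number from compound 1 to compound 2 (1.58 log units; beyond the scatter) shows that the move from a diethylamino group to a 2-(methylamino)ethyl chain changes the read-out strongly, and a 13-fold higher number from compound 2 to compound 3 (1.12 log units; beyond the scatter) shows that adding ethyl on the carbon bound to the amine nitrogen raises the number again.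

Compound 4, `NCCCCCCc1c[nH]c2ccc(F)cc12`, is not yet measured. It differs from compound 3 by 3-aminopropyl in place of propylamino on a saturated chain carbon, three bonds along the chain from an aromatic carbon. Compound 4 carries no substituent on the amine nitrogen, which in compound 2 went with the lowest number shown; the chain to the amine, however, is longer than in any measured compound. Both measured steps bear on this change only in part, so a moderate step is expected, towards a lower number than compound 3. Compound 4 is estimated at 120 nM, within 25 nM to 600 nM, meaning an expected step of a 2.8-fold lower number from compound 3 to compound 4 (0.45 log units; beyond the scatter).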

Compound 4, half-maximal inhibitory concentration: 580 nM
Compound 4: the middle estimate sits 4.8-fold (0.68 log units) below what was measured, and the stated range covers the measured number.
By their numbers in this assay, from the lowest: compound 2; then compounds 3 and 4 (each within the scatter of the next). At a limit, above all of these: compound 1.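

Moving the nitrogen along the chain, with the atoms otherwise unchanged, gives a 1.7-fold higher number from compound 3 to compound 4 (0.23 log units; within the scatter), so in this assay 3-aminopropyl and propylamino at this place on a saturated chain carbon cannot be told apart. Going by these compounds alone, the comparison with the methylamino compound is clearer: a 22-fold higher number from compound 2 to compound 4 (1.35 log units; beyond the scatter) shows that a terminal amine on the longer chain does not bring the number back to that of compound 2, which remains the only one of the measured compounds at 26 nM, with compound 3 and compound 4 together well apart from it. Nothing at hand gives a cause for either of these steps.

The compounds shown leave open how an unsubstituted amino group or a dimethylamino group would read in this assay on the chain of compound 2, a comparison that would separate substitution on the nitrogen from the length of the chain. Also open, going by these compounds, is whether a chain ending in a hydroxyl group or a carboxylic acid in place of the amine would hold any of this inhibition.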